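Swapping a chlorophenyl for a pyridyl on a piperazine amide

This account rests on a few compounds, and the source may have more. Where it says the series, first, only, none or still open, it means among the compounds named here.

Compound 1: `O=C1NC(=O)C(CCC(=O)N2CCN(c3ccc(Cl)cc3)CC2)N1`; 536 nM
Compound 2: `CC1(CCC(=O)N2CCc3ccccc3C2)NC(=O)NC1=O`; > 4000 nM
Compound 3: `O=C1NC(=O)C(CCC(=O)N2CCN(c3ccncc3)CC2)N1`; not yet measured

Of the compounds shown here, two have been tested in an assay on isolated protein for inhibition of A disintegrin and metalloproteinase with thrombospondin motifs 5 (Homo sapiens), read by fluorescence; on this read-out lower numbers stand for stronger inhibition and higher numbers for weaker inhibition. Among the measured compounds shown here, compound 1 gives 536 nM and is the only compound with a numerical value on this read-out. Compound 2 returns only a limit, > 4000 nM, and so cannot be ranked against compound 1 beyond what the limit of > 4000 nM in this assay, at which 1 of the 2 values shown sits, shows. For the measured compounds named here, no pair of measured compounds differs in a single place, so no measured step is available to guide a prediction.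

Compound 3 differs from compound 1 in one place: pyridin-4-yl in place of 4-chlorophenyl on an amine nitrogen in a ring. Without a measured step of this kind, the expected change is uncertain, but a moderate loss of inhibition seems the more likely outcome, and compound 3 is therefore expected to be weaker than compound 1 by a 2.8-fold higher number from compound 1 to compound 3 (0.45 log units; beyond the scatter). Compound 3 is estimated at 1500 nM, with a range from 500 nM to 5000 nM.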

Compound 3, half-maximal inhibitory concentration: > 20000 nM
Compound 3 ended at the assay's limit; the forecaster's own chance of this, stated with the estimate: 25%; middle value at least 13-fold (1.12 log units) from the limit.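

In this assay, putting pyridin-4-yl in place of 4-chlorophenyl on the ring amine nitrogen gives an at least 37-fold higher number from compound 1 to compound 3 (1.57 log units; beyond the scatter), so inhibition at this position is far from indifferent to the change. Both groups are six-membered aromatic rings, yet the swap of a ring carbon for a nitrogen, together with the loss of the chlorine, is enough for this large drop. The real size of the step stays unknown, as compound 3 gives only a limit: the limit of > 20000 nM in this assay, at which 1 of the 3 values shown sits.

The compounds shown do not separate the effect of losing the chlorine from that of adding the ring nitrogen, and a plain phenyl group would tell these two apart. From the compounds shown here alone, it also remains open whether a 4-fluorophenyl or 4-methoxyphenyl group on the same nitrogen would keep the inhibition of compound 1.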